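Swapping the sulfonyl aryl group on a shared pyrrole core

The source may report more compounds than this note shows. Statements on the series, on what has been measured and on what is new or still open speak of the compounds shown alone.

Compound 2 `CNCc1cc(-c2cccnc2F)n(S(=O)(=O)c2ccccn2)c1` gives 81% in a functional assay on the whole organism (strain Jcl:SD) for inhibition, with Rattus norvegicus as the target, with stated times of 3 min and 3 h, at a dose of 1 mg/kg by the intravenous route (a higher number here means more inhibition at the dose given (going by the name of the read-out), a lower number less inhibition), and it stands lowest of the two measured numbers. Its neighbour compound 1 `CNCc1cc(-c2cccnc2F)n(S(=O)(=O)c2cccc(C#N)c2)c1` gives 99%, so the measured step of a number 18 percentage points lower from compound 1 to compound 2 (beyond the scatter) shows that the aryl group on the sulfonyl sulfur can shift the inhibition by a modest amount beyond the scatter. Compound 3 `CNCc1cc(-c2cccnc2F)n(S(=O)(=O)c2ccc(OC)nc2)c1` is not yet measured; it differs from compound 2 in one place (6-methoxypyridin-3-yl in place of pyridin-2-yl on a sulfonyl sulfur). Among the compounds with values here, no measured step covers this exact exchange, so the only guide is that a single change at this position moved the number once before. The expectation for compound 3 is a small rise, a number 7 percentage points higher from compound 2 to compound 3 (within the scatter), with considerable uncertainty in either direction. Compound 3 is therefore estimated at 88%, between 68% and 99%.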

Compound 3, a percentage reported as inhibition, in the whole organism at one dose (the size of the read-out at that dose, not a potency) in the Rattus norvegicus assay: 97%
Compound 3: middle estimate off by 9 percentage points, on the low side; low and high end bracket the measured number.
By their numbers in the Rattus norvegicus assay, from the lowest: compound 2; then compounds 3 and 1 (each within the scatter of the next).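

In the Rattus norvegicus assay the 6-methoxypyridin-3-yl group gives a number 16 percentage points higher from compound 2 to compound 3 (beyond the scatter) and thus shows that the aryl group on the sulfonyl sulfur can raise the inhibition as well as lower it, while a number 2 percentage points lower from compound 1 to compound 3 (within the scatter) places this group level with 3-cyanophenyl. In a physicochemical assay for lipophilicity, read by HPLC, at pH 7.4 (on this read-out higher numbers stand for higher lipophilicity and lower numbers for lower lipophilicity), compound 2 gives 0.05 and compound 3 gives 0.24 with a number 0.19 log units higher from compound 2 to compound 3 (within the scatter) and so the step in inhibition comes without a step beyond the scatter in this distribution coefficient. No measurement here accounts for the gap in inhibition between the two groups.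

Compound 3 differs from compound 2 in both the methoxy group and the ring's point of attachment, and the compounds shown do not separate these two changes. From the compounds shown here alone, whether an unsubstituted pyridin-3-yl or a 6-aminopyridin-3-yl group would hold the inhibition also remains open.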